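Ring Size on the Chain Carbon: Compound 3 to Compound 4

A few compounds are considered here, and "the series" means these few. Any claim that something is new, unique, unknown or untested is made for them only; others in the source may bear on it.

Three compounds built on one shared core have been examined in an ADME assay on microsomes from liver (Homo sapiens) for metabolic stability; a lower number here means that the compound disappears faster, a higher number that the compound lasts longer. Compound 3 `O=C1NC(=O)/C(=C/C(c2ccc(-c3ccc4cccc(F)c4c3)[nH]c2=O)C2CC2)O1` gives 1.98 h in this assay. Among the compounds with values here, compound 1 `CC(C)(/C=C1\OC(=O)NC1=O)c1ccc(-c2ccc3cccc(F)c3c2)[nH]c1=O` gives 1.89 h, a number that sits within the scatter of the one for compound 3, so the two cannot be placed in order. Compound 2 `CC(C)/C(=C1\C(=O)NC(=O)N1C)c1ccc(-c2ccc3cccc(F)c3c2)[nH]c1=O` returns (the limit of > 3 h in this assay, at which 1 of the 3 values shown sits), a limit of the assay and not a number. For compound 2 the read-out in this assay is therefore > 3 h.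

Compound 4 `O=C1NC(=O)/C(=C/C(c2ccc(-c3ccc4cccc(F)c4c3)[nH]c2=O)C2CCCCC2)O1` has not yet been measured. It differs from compound 3 by cyclohexyl in place of cyclopropyl on a saturated chain carbon bound to an aromatic carbon and a double-bonded chain carbon. Within the data shown here, no measured pair differs in only this way, so nothing shows the size of such a step. The step from compound 3 to compound 4 is expected to be a modest shortening of the half-life, a 1.7-fold lower number from compound 3 to compound 4 (0.22 log units; within the scatter), though a change no larger than the scatter cannot be ruled out. The estimated value for compound 4 in this assay is 1.2 h, with a likely range from 0.5 h to 2.8 h.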

Compound 4, half-life: 1.09 h
Compound 4: middle estimate off by 1.1-fold (0.04 log units), on the high side; measured number inside the range.
By their numbers in this assay, from the lowest: compounds 4, 1 and 3 (each within the scatter of the next). At a limit, above all of these: compound 2.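

Within the data shown here, this is the first pair that differs only on the saturated chain carbon bound to an aromatic carbon and a double-bonded chain carbon, and it gives a size for a ring change there in this assay: a 1.8-fold lower number from compound 3 to compound 4 (0.26 log units; within the scatter). Cyclohexyl in place of cyclopropyl therefore leaves the two half-lives within the scatter of each other, so this change cannot be said to have shortened the half-life, and the pair sets no order between the two rings. Nothing measured here bears on a cause for this step.

Going by these compounds, it remains open whether a ring of in-between size, such as cyclobutyl or cyclopentyl, would behave like these two rings. On these data alone, it also remains open whether an amine or a longer chain on this carbon would move the half-life beyond the scatter.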